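A chloro group added to compound 1

This account rests on a few compounds, and the source may have more. Where it says the series, first, only, none or still open, it means among the compounds named here.

Within the data shown here, in a functional assay on the whole organism with Mus musculus as the target, in the maximal electroshock model (on this read-out higher numbers stand for an effect only at larger amounts of compound and lower numbers for an effect already at smaller amounts), compound 1 (`C[C@@H](NCc1ccc(OCc2ccccc2)cc1)C(N)=O`) gives 17.1 mg/kg, the higher of the two numbers available so far. Compound 2 (`CC[C@@H](NCc1ccc(OCc2ccccc2)cc1)C(N)=O`) gives 7.2 mg/kg.

Compound 3 (`C[C@@H](NCc1ccc(OCc2ccccc2Cl)cc1)C(N)=O`) has not yet been measured. It keeps the core of compound 1 and changes one place: chloro in place of hydrogen on an aromatic carbon. Cut one bond further out, the same difference reads phenyl to 2-chlorophenyl.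

Among the measured compounds shown here, only one measured step is available, a 2.4-fold lower number from compound 1 to compound 2 (0.38 log units; beyond the scatter). That step is a methyl in place of hydrogen on a saturated chain carbon, so it lies elsewhere in the molecule and bears on the new change only indirectly. For the measured compounds named here, no measured step shows what a substituent on the aromatic ring does, which leaves the direction poorly defined. Going by the values given here, the one step does offer a rough sense of scale, and a change of similar or smaller size seems a reasonable expectation.

The expected change is a 1.2-fold lower number from compound 1 to compound 3 (0.09 log units; within the scatter). For compound 3 the estimated value is 14 mg/kg, with an expected range from 6 mg/kg to 32 mg/kg.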

Compound 3, dose for half-maximal effect: 50.8 mg/kg
Compound 3: middle estimate off by 3.6-fold (0.56 log units), on the low side; measured number outside the range, above it.
By their numbers in this assay, from the lowest: compound 2; then compound 1; then compound 3.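

In this assay, among these compounds, the chloro group gives the first reading of a change on this aromatic ring: a 3.0-fold higher number from compound 1 to compound 3 (0.47 log units; beyond the scatter). Going from phenyl to 2-chlorophenyl therefore means that an effect appears only at a larger amount of compound, so this place on the ring does not tolerate every added atom without consequence for this read-out. The step runs opposite to the one on the saturated chain, a 2.4-fold lower number from compound 1 to compound 2 (0.38 log units; beyond the scatter), so the two single changes made to compound 1 move the number in opposite directions, and nothing available explains why the chloro group has this effect.

The compounds shown leave open whether the step belongs to chlorine itself or would also follow from another group in the same place, such as fluoro, methyl or methoxy. They also leave open whether the chloro group would produce a similar step on the core of compound 2, whose methyl-extended chain gives the lowest number here, so the two changes cannot yet be judged together.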